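A few compounds are considered here, and "the series" means these few. Any claim that something is new, unique, unknown or untested is made for them only; others in the source may bear on it.

Three analogues sharing one core have been measured in an assay on isolated protein for inhibition of histone deacetylase 4 (Homo sapiens), with a stated time of 1 h; a higher number here means a weaker inhibitor, a lower number a stronger inhibitor. Compound 1 `Cc1cc(Br)ccc1NC(=O)COc1ccc2cc(/C=C3/SC(=O)NC3=O)ccc2c1` gives 550 nM, compound 2 `O=C(COc1ccc2cc(/C=C3/SC(=O)NC3=O)ccc2c1)Nc1ccc(F)cc1` gives 1600 nM, and compound 3 `O=C(COc1ccc2cc(/C=C3/SC(=O)NC3=O)ccc2c1)Nc1ccc(Cl)c(Cl)c1` gives 5500 nM, the highest of the three numbers, with a 10-fold higher number from compound 1 to compound 3 (1.00 log units; beyond the scatter) and a 3.4-fold higher number from compound 2 to compound 3 (0.54 log units; beyond the scatter). Compound 4 `O=C(COc1ccc2cc(/C=C3/SC(=O)NC3=O)ccc2c1)Nc1cccc(Cl)c1` differs from compound 3 by hydrogen in place of chloro on an aromatic carbon. Going by the values given here, no measured step removes a single chloro; the nearest guide is that a 4-fluorophenyl group gave a 3.4-fold higher number from compound 2 to compound 3 (0.54 log units; beyond the scatter), a modest change, so trimming compound 3 back toward a smaller aryl group is expected to lower the number modestly, though perhaps not beyond the scatter. Compound 4 is therefore estimated at 2500 nM in this assay, within 900 nM to 7000 nM, an expected step of a 2.2-fold lower number from compound 3 to compound 4 (0.34 log units; beyond the scatter).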

Compound 4, half-maximal inhibitory concentration: 3800 nM
Compound 4: the middle estimate sits 1.5-fold (0.18 log units) below what was measured, and the stated range covers the measured number.
By their numbers in this assay, from the lowest: compound 1; then compound 2; then compounds 4 and 3 (each within the scatter of the next).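

In this assay, replacing this chloro, para to a large group, with hydrogen gives a 1.4-fold lower number from compound 3 to compound 4 (0.16 log units; within the scatter) and so leaves compound 3 and compound 4 indistinguishable. The remaining 3-chlorophenyl compound still falls short of the other two, with a 2.4-fold higher number from compound 2 to compound 4 (0.38 log units; beyond the scatter) and a 6.9-fold higher number from compound 1 to compound 4 (0.84 log units; beyond the scatter) as the gaps, so these gaps do not rest on the chloro removed here. No measurement offered here explains this result. Still open, from the compounds shown here alone, is how a plain phenyl ring without chloro would compare, and whether a methoxy or amino group at this position would shift the number.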